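Anilino-quinone series: sulfamoyl for methoxyphenyl on the anilino ring

This account rests on a few compounds, and the source may have more. Where it says the series, first, only, none or still open, it means among the compounds named here.

Three compounds share one core. Compound 1 `COc1cc(NC2=CC(=O)c3ncncc3C2=O)cc(OC)c1` gives 7200 nM in a functional assay on PANC-1 cells (Homo sapiens) for cytotoxicity, read by MTT assay, with a stated time of 72 h; on this read-out higher numbers stand for weaker inhibition and lower numbers for stronger inhibition; compound 3 `COc1cccc(NC2=CC(=O)c3ncncc3C2=O)c1` gives 600 nM. Among the measured compounds shown here, the one single-point step, a 12-fold lower number from compound 1 to compound 3 (1.08 log units; beyond the scatter), is large. Compound 2 `COc1ccc(-c2ccc(NC3=CC(=O)c4ncncc4C3=O)cc2)cc1` gives 2300 nM, second highest of the three numbers, beyond the scatter from both compound 1 and compound 3. Compound 4 `NS(=O)(=O)c1ccc(NC2=CC(=O)c3ncncc3C2=O)cc1` differs from compound 2 by sulfamoyl in place of 4-methoxyphenyl on an aromatic carbon. For the measured compounds named here, no measured step bears directly on this change: the only step known concerns a methoxy on the anilino ring, not a replacement of the para group, so the direction is open. A step within the scatter is expected, a 1.3-fold lower number from compound 2 to compound 4 (0.11 log units; within the scatter). Compound 4 is estimated at 1800 nM, range 500 nM to 6500 nM.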

Compound 4, half-maximal inhibitory concentration: > 10000 nM
Compound 4 gave a limit, no number; the forecaster's own chance of this, stated with the estimate: 5%; middle value at least 5.5-fold (0.74 log units) away from the limit.
By their numbers in this assay, from the lowest: compound 3; then compound 2; then compound 1. At a limit, above all of these: compound 4.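

Among the compounds shown here, the earlier compounds showed nothing about this position; the first reading on it in this assay is an at least 4.3-fold higher number from compound 2 to compound 4 (0.63 log units; beyond the scatter). Compound 4 gives > 10000 nM, which is a limit of the assay and not a number. Sulfamoyl therefore does not match 4-methoxyphenyl at this position, and the full size of the step stays unknown, as the reading rests on a limit: the limit of > 10000 nM in this assay, at which 1 of the 4 values shown sits.

As far as these compounds go, whether this weakening comes from sulfamoyl entering or from 4-methoxyphenyl leaving remains open. A carboxylic acid or an amine on the same aromatic carbon would help separate the two.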